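Hydroxy for hydrogen on a chain: lipophilicity notes

The source may report more compounds than this note shows. Statements on the series, on what has been measured and on what is new or still open speak of the compounds shown alone.

Measured compounds:
compound 1 `CCc1ccc2c(c1)C=CN(C)C(=O)[C@@H]2C`, 5.9
compound 2 `C[C@H]1C(=O)N(C)C=Cc2cc(CCO)ccc21`, 2.6
compound 3 `CCOc1ccc2c(c1)C(c1c[nH]c(C)n1)=CN(C)C(=O)[C@@H]2C`, 3.1

In a physicochemical assay for lipophilicity, at pH 7.4 (on this read-out higher numbers stand for higher lipophilicity and lower numbers for lower lipophilicity), compound 1 gives 5.9, compound 2 gives 2.6 and compound 3 gives 3.1, so on the values alone compound 3 lies between the other two, closer to compound 2. The change from compound 1 to compound 2 is hydroxy in place of hydrogen on a saturated chain carbon, two bonds along the chain from an aromatic carbon and it made the step of a number 3.30 log units lower from compound 1 to compound 2 (beyond the scatter).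

Compound 4 `Cc1nc(C2=CN(C)C(=O)[C@H](C)c3ccc(OCCO)cc32)c[nH]1` is not yet measured in this assay. It differs from compound 3 by hydroxy in place of hydrogen on a saturated chain carbon, two bonds along the chain from an oxygen on an aromatic ring. Among the compounds with values here, this is the same kind of change as the one from compound 1 to compound 2, not the same: there the place is two bonds along the chain from an aromatic carbon, here it is two bonds along the chain from an oxygen on an aromatic ring. The difference between the core of compound 3 and the core of compound 1 is not broken down here.

Within the data shown here, because the one measured instance is the step of a number 3.30 log units lower from compound 1 to compound 2 (beyond the scatter), a drop is expected from compound 3 to compound 4. Among the measured compounds shown here, the expected step is a number 1.20 log units lower from compound 3 to compound 4 (beyond the scatter), smaller than the measured one, because the single measured step of a number 3.30 log units lower from compound 1 to compound 2 (beyond the scatter) sits at the far end of what such a change usually gives. Compound 4 is therefore estimated at 1.9, between 1 and 2.8.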

Compound 4, distribution coefficient: 1.5
Compound 4: middle estimate off by 0.40 log units, on the high side; measured number inside the range.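

In this assay, hydroxy in place of hydrogen gives a number 1.60 log units lower from compound 3 to compound 4 (beyond the scatter), which matches the direction of a number 3.30 log units lower from compound 1 to compound 2 (beyond the scatter), so across these two pairs the change lowers the read-out on both cores, though the drop is smaller on the core of compound 3. The two steps differ in both core and place, one being two bonds along the chain from an aromatic carbon and the other two bonds along the chain from an oxygen on an aromatic ring, so two pairs cannot show whether the core, the place or both set the size of the step, and they establish no general rule for the series. Nothing available accounts for the difference in size.

Still open, going by these compounds, is whether an amine or a carboxylic acid in place of the hydroxy would move the read-out in the same direction on either core. Also open, on these data alone, is how a longer chain carrying the hydroxy would compare with 2-hydroxyethoxy on the core of compound 3.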